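Bromo in Place of Chloro on a Shared Core

The source may report more compounds than this note shows. Statements on the series, on what has been measured and on what is new or still open speak of the compounds shown alone.

Compound 1, `COc1ccc(Oc2ccc3nncn3n2)cc1`, shows in a functional assay on the whole organism with Mus musculus as the target (on this read-out lower numbers stand for an effect already at smaller amounts and higher numbers for an effect only at larger amounts of compound), only a limit, > 100 mg/kg.
Compound 2, `Fc1ccc(Oc2ccc3nncn3n2)cc1`, gives in this assay 38 mg/kg.
Compound 3, `Clc1ccc(Oc2ccc3nncn3n2)cc1`, gives in this assay 36.7 mg/kg.

Compound 3 and compound 2 lie within the scatter of each other, so neither can be called more or less active than the other; compound 1 stands apart only through its limit (the limit of > 100 mg/kg in this assay, at which 1 of the 3 values shown sits). Compound 4, `Brc1ccc(Oc2ccc3nncn3n2)cc1`, is not yet measured. It differs from compound 3 in one place: bromo in place of chloro on an aromatic carbon.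

Of the measured steps, the closest parallel is the exchange of one halogen for another, a 1.0-fold lower number from compound 2 to compound 3 (0.02 log units; within the scatter), which produced no change beyond the scatter. The two steps that did move the number, an at least 2.6-fold lower number from compound 1 to compound 2 (0.42 log units; beyond the scatter) and an at least 2.7-fold lower number from compound 1 to compound 3 (0.43 log units; beyond the scatter), both replaced methoxy by a halogen and so do not match the present change, which keeps a halogen and only enlarges it. On this basis the step from compound 3 to compound 4 is expected to stay within the scatter, with no clear direction, an estimated 1.0-fold lower number from compound 3 to compound 4 (0.02 log units; within the scatter).

For compound 4 in this assay the expected value is therefore 35 mg/kg, with a range from 17 mg/kg to 75 mg/kg.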

Compound 4, dose for half-maximal effect: 49.1 mg/kg
The estimate for compound 4 lay 1.4-fold (0.15 log units) below the measured number; low and high end bracket the measured number.
By their numbers in this assay, from the lowest: compounds 3, 2 and 4 (each within the scatter of the next). At a limit, above all of these: compound 1.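

Fluoro, chloro and bromo at this position now give three values in this assay that all lie within the scatter of one another, as the two new halogen steps confirm (a 1.3-fold higher number from compound 3 to compound 4 (0.13 log units; within the scatter)) and (a 1.3-fold higher number from compound 2 to compound 4 (0.11 log units; within the scatter)). Before compound 4, this rested on a single pair of halogens; now, across all three, the choice of halogen makes no difference that this assay can resolve. For the compounds shown here, the step from methoxy to bromo (an at least 2.0-fold lower number from compound 1 to compound 4 (0.30 log units; that floor lies within the scatter)) is less firm than the earlier steps from methoxy to fluoro and to chloro, which were beyond the scatter, and its floor cannot separate compound 4 from compound 1, since compound 1 gives only a limit and not a number: (the limit of > 100 mg/kg in this assay, at which 1 of the 4 values shown sits).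

The compounds shown keep the shared core fixed and vary only this one place, so they leave open whether an amine, a carboxylic acid or a longer chain such as butoxy here would move the number beyond the scatter. Going by these compounds, how far compound 1 truly lies from the three halogen compounds also stays open, as does what plain hydrogen at this place would give.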